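A Methylpiperazine Side Chain in Place of Methoxy

This account rests on a few compounds, and the source may have more. Where it says the series, first, only, none or still open, it means among the compounds named here.

For the measured compounds named here, in an ADME assay on MT4 cells (Homo sapiens) for cytotoxicity, read by MTT assay, with a stated time of 5 days (on this read-out higher numbers stand for lower toxicity in this test and lower numbers for higher toxicity in this test), compound 2 `COCCNc1cc(Oc2c(C)cc(/C=C/C#N)cc2C)cc(Nc2ccc(C#N)cc2)n1` gives 58200 nM, the higher of the two numbers measured so far, while compound 1 `Cc1cc(/C=C/C#N)cc(C)c1Oc1cc(Nc2ccc(C#N)cc2)nc(NC2CC2)c1` gives 24800 nM. Compound 3 `Cc1cc(/C=C/C#N)cc(C)c1Oc1cc(NCCN2CCN(C)CC2)nc(Nc2ccc(C#N)cc2)c1` differs from compound 2 only in its side chain: 4-methylpiperazin-1-yl in place of methoxy on a saturated chain carbon, two bonds along the chain from a nitrogen on an aromatic ring. Put another way, 2-methoxyethyl becomes 2-(4-methylpiperazin-1-yl)ethyl. Going by the values given here, only one measured step bears on this change, a 2.3-fold higher number from compound 1 to compound 2 (0.37 log units; beyond the scatter), which was modest and also concerned the group on a nitrogen on an aromatic ring. Among the compounds with values here, no measured compound carries the 4-methylpiperazin-1-yl group, so this is thin evidence, and the direction is a judgement. A modest step of similar size towards a lower number is expected, namely a 2.3-fold lower number from compound 2 to compound 3 (0.37 log units; beyond the scatter). For compound 3 the estimate is 25000 nM, with an expected range of 9000 nM to 65000 nM.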

Compound 3, half-maximal cytotoxic concentration: 7960 nM
Estimate against measurement, compound 3: 3.1-fold (0.50 log units) above, outside the stated range (below it).
By their numbers in this assay, from the lowest: compound 3; then compound 1; then compound 2.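

In this assay, the side chain proves able to push the number down as well as up: the earlier step at this nitrogen, a 2.3-fold higher number from compound 1 to compound 2 (0.37 log units; beyond the scatter), went upward, whereas 4-methylpiperazin-1-yl in place of methoxy gives a 7.3-fold lower number from compound 2 to compound 3 (0.86 log units; beyond the scatter), which here means higher toxicity in this test. The 2-(4-methylpiperazin-1-yl)ethyl group also falls below the cyclopropyl group, with a 3.1-fold lower number from compound 1 to compound 3 (0.49 log units; beyond the scatter), so compound 3 holds the lowest number of the three, beyond the scatter from both others. Nothing available explains why this change lowers the number.

The compounds shown leave open whether the drop follows the saturated ring as a whole or its methyl-bearing nitrogen. A morpholine, an unsubstituted piperazine or a simple dimethylamino group at the same chain end would separate these, and a longer chain would test the distance from the aromatic ring.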